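This account rests on a few compounds, and the source may have more. Where it says the series, first, only, none or still open, it means among the compounds named here.

Compound 1 `CC(C)=CCC[C@]1(C)/C=C/[C@@H](OC(=O)C=C(C)C)[C@](C)(O)/C=C/C(=O)/C(CN(C)C)=C\C1` sets the reference point in this series. In a functional assay on SW480 cells (Homo sapiens) for antiproliferative activity, read by MTT assay, with a stated time of 48 h (on this read-out higher numbers stand for weaker inhibition and lower numbers for stronger inhibition), compound 1 gives 480 nM, the lowest of the two numbers in hand. Compound 3 `CC(C)=CCC[C@](C)(/C=C/[C@@H](OC(=O)C=C(C)C)[C@](C)(O)/C=C/C(=O)/C=C/N(C)C)CC=O` carries a ring-opened core ending in an aldehyde, and in this assay compound 3 gives 10300 nM, a gap to compound 1 that lies beyond the scatter. Compound 2 `CC(C)=CCC[C@]1(C)/C=C/[C@@H](OC(=O)C=C(C)C)[C@](C)(O)CCC(=O)/C(CO)=C\C1` bears a hydroxymethyl group on the ring and a saturated link to the hydroxy-bearing carbon; in this assay compound 2 reaches only the limit > 40000 nM, which is a limit of the assay and not a number (the limit of > 40000 nM in this assay, at which 1 of the 3 values shown sits). Among the measured compounds shown here, since compound 2 differs from compound 1 in two places, its value shows only that the pair sits far apart.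

Compound 4 `CC(C)=CCC[C@]1(C)/C=C/[C@@H](OC(=O)C=C(C)C)[C@](C)(O)/C=C/C(=O)/C(C(=O)N2CCCC2)=C\C1` is the next step from compound 1: (pyrrolidin-1-yl)carbonyl in place of (dimethylamino)methyl on a double-bonded ring carbon. For the measured compounds named here, no measured pair isolates this kind of exchange, so the expectation rests on the spread seen so far. Compound 4 is expected to lose ground, with a step from a 6.3-fold higher number from compound 1 to compound 4 (0.80 log units; beyond the scatter) in the direction of weaker inhibition. For compound 4 the estimate in this assay is 3000 nM, expected between 700 nM and 15000 nM.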

Compound 4, half-maximal inhibitory concentration: 15100 nM
Estimate against measurement, compound 4: 5.0-fold (0.70 log units) below, outside the stated range (above it).
By their numbers in this assay, from the lowest: compound 1; then compounds 3 and 4 (each within the scatter of the next). At a limit, above all of these: compound 2.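

In this assay, (pyrrolidin-1-yl)carbonyl in place of (dimethylamino)methyl on the double-bonded ring carbon brings a 31-fold higher number from compound 1 to compound 4 (1.50 log units; beyond the scatter), in the direction of weaker inhibition. Among the compounds shown here, this is the first comparison that changes one place only, and it shows that the value depends strongly on the group at this ring carbon, which the earlier compounds, each differing from compound 1 in more than one place, could not show. Nothing measured here accounts for the size of this step.

The carbonyl and the pyrrolidine ring enter together, so the compounds shown leave open which of them goes with the step; (pyrrolidin-1-yl)methyl or (dimethylamino)carbonyl at the same ring carbon would separate the two. Also open, from the compounds shown here alone, is how a primary aminomethyl or a morpholin-4-ylmethyl group would fare there.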